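The source may hold more compounds than are shown below. What is called first, only, known or untested is meant among the compounds shown, and "the series" means these compounds.

Going by the values given here, compound 2 `COc1cc(Cl)cc(-c2nn(-c3cccc(NC(=O)Nc4ccc(Cl)c(Cl)c4)c3)cc2-c2ccncc2)c1` stands, on the two numbers so far obtained in a functional assay on Hs-578T cells (Homo sapiens) for inhibition, read by sulforhodamine B assay, with a stated time of 48 h, tested at 10 uM (a higher number here means a weaker effect of the compound at the concentration tested, a lower number a stronger effect), as the weaker of the pair: in this assay compound 2 gives 28.5%, whereas compound 1 `COc1cc(Cl)cc(-c2nn(-c3cccc(NC(=O)Nc4ccc(Cl)c(C(F)(F)F)c4)c3)cc2-c2ccncc2)c1` gives 14.6%. Among the compounds with values here, the only measured step, a number 13.9 percentage points higher from compound 1 to compound 2 (beyond the scatter), is the sole guide available, and it tells that exchanging a trifluoromethyl for a chloro on an aromatic carbon cost activity.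

Compound 3 `COc1cc(Cl)cc(-c2nn(-c3cccc(NC(=O)c4cccc(C(F)(F)F)c4)c3)cc2-c2ccncc2)c1` is not yet measured. It differs from compound 2 in one place: 3-(trifluoromethyl)phenyl in place of (3,4-dichlorophenyl)amino on a carbonyl carbon. Cut one bond further out, the change reads (3,4-dichlorophenyl)carbamoyl to (3-(trifluoromethyl)phenyl)carbonyl. The measured step bears only loosely: it compared trifluoromethyl with chloro, and the trifluoromethyl side was stronger, but here the whole (3,4-dichlorophenyl)amino portion leaves and the amide-type nitrogen is no longer joined to the ring through the carbonyl in the same way. Because the return of trifluoromethyl mirrors a number 13.9 percentage points higher from compound 1 to compound 2 (beyond the scatter) in reverse while the larger change is uncovered, a modest step toward weaker activity, a number 16.5 percentage points higher from compound 2 to compound 3 (beyond the scatter), is expected. For compound 3 the estimate is 45%, between 20% and 75%.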

Compound 3, a percentage reported as activity, at one concentration (the size of the read-out at that concentration, not a potency): 62.2%
For compound 3 the middle estimate is 17.2 percentage points below the measured one; low and high end bracket the measured number.
By their numbers in this assay, from the lowest: compound 1; then compound 2; then compound 3.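

In this assay, the step of a number 33.7 percentage points higher from compound 2 to compound 3 (beyond the scatter) and the step of a number 47.6 percentage points higher from compound 1 to compound 3 (beyond the scatter) show that this carbonyl carbon tolerates the loss of the arylamino portion far less well than the aromatic carbon of the earlier step tolerated chloro in place of trifluoromethyl, where the change was only modest. The trifluoromethyl group present in compound 3 does not bring back the stronger effect of compound 1, so on these compounds that group alone does not carry the effect, and the change as a whole, which also removes the amino nitrogen and its hydrogen-bond donor, weakens the effect from either starting point. Nothing available explains why this exchange weakens the effect so much.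

The compounds shown leave open whether the loss follows the amino nitrogen or the altered substitution on the ring, as the two change together in both steps. As far as these compounds go, a (3-(trifluoromethyl)phenyl)amino group or a 3-(trifluoromethyl)benzyl group on the same carbonyl carbon would bear on that question, and the effect of either is unknown here.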